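Replacing a Fluorinated Benzyl Group with a Nitrile-Bearing One

The source may hold more compounds than are shown below. What is called first, only, known or untested is meant among the compounds shown, and "the series" means these compounds.

Compound 1, `O=C(O)c1ccccc1-c1ccc(CCc2ncc(CC3CCCCC3)[nH]2)cc1`: 41 nM
Compound 2, `O=C(O)c1ccccc1-c1ccc(CCc2ncc(Cc3ccccc3F)[nH]2)cc1`: 177 nM

In an in vitro functional assay on cells for agonist activity at Bombesin receptor subtype-3 (Homo sapiens), read by luminescence and calcium flux (a lower number here means that less compound is needed, a higher number that more compound is needed for the effect), compound 1 gives 41 nM, while compound 2 gives 177 nM. Among the compounds with values here, compound 2 holds the higher of the two numbers, and the single measured step, a 4.3-fold higher number from compound 1 to compound 2 (0.64 log units; beyond the scatter), is all that separates it from compound 1.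

Compound 3, `N#Cc1ccc(Cc2cnc(CCc3ccc(-c4ccccc4C(=O)O)cc3)[nH]2)cc1`, differs from compound 2 by 4-cyanophenyl in place of 2-fluorophenyl on a saturated chain carbon bound to an aromatic carbon. Within the data shown here, the one step on record exchanged cyclohexyl for an aromatic ring at this carbon; it does not speak to swapping one aromatic ring for another, nor to moving a single substituent around such a ring. Among the measured compounds shown here, the data give no step of that kind, so the change from compound 2 to compound 3 is unprecedented within this set. With nothing pointing in either direction, the reasonable expectation is no step beyond the scatter, though with a wide margin.

Near compound 2, then, compound 3 is expected at 200 nM, within a range of 50 nM to 800 nM. The implied step, a 1.1-fold higher number from compound 2 to compound 3 (0.05 log units; within the scatter), is expected to fall within the scatter.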

Compound 3, half-maximal effective concentration: 5890 nM
Compound 3: the middle estimate sits 29-fold (1.47 log units) below what was measured, outside the stated range (above it).
By their numbers in this assay, from the lowest: compound 1; then compound 2; then compound 3.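

In this assay this position proves far less forgiving than the first pair suggested: exchanging one substituted aromatic ring for another gives a 33-fold higher number from compound 2 to compound 3 (1.52 log units; beyond the scatter) and so outstrips the step of a 4.3-fold higher number from compound 1 to compound 2 (0.64 log units; beyond the scatter) that came with putting an aromatic ring in place of cyclohexyl. Against cyclohexyl itself, 4-cyanophenyl gives a 140-fold higher number from compound 1 to compound 3 (2.16 log units; beyond the scatter) and thus spreads the three groups on this saturated chain carbon bound to an aromatic carbon very widely, with cyclohexyl at the low end and 4-cyanophenyl at the high end, so the presence of an aromatic ring alone does not set the number here. Nothing available accounts for the size of this jump.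

The step from 2-fluorophenyl to 4-cyanophenyl changes both the substituent and its place on the ring, and the compounds shown cannot separate these two changes. In this assay, on these data alone, it also stays open how an unsubstituted phenyl ring or a methoxy group on that ring would read, and whether any aromatic group at this carbon can match cyclohexyl.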